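The source may report more compounds than this note shows. Statements on the series, on what has been measured and on what is new or still open speak of the compounds shown alone.

In a functional assay on A-375 cells (Homo sapiens) for antiproliferative activity (on this read-out lower numbers stand for stronger inhibition and higher numbers for weaker inhibition), compound 1 `CCCO/N=C/c1c(N)ncnc1Oc1ccc2[nH]c(C)cc2c1F` gives 28 nM, compound 2 `Cc1cc2c(F)c(Oc3ncnc(N)c3/C=N/OCCCO)ccc2[nH]1` gives 336 nM, and compound 3 `CO/N=C/c1c(N)ncnc1Oc1ccc2[nH]ccc2c1` gives 783 nM. Among these three numbers compound 2 stands second highest, nearer to compound 3 than to compound 1. Among the compounds with values here, only one measured step involves a single structural change: a 12-fold higher number from compound 1 to compound 2 (1.08 log units; beyond the scatter), arising from a hydroxy in place of hydrogen on a saturated chain carbon, three bonds along the chain from an oxygen. Compound 4 `COCCCO/N=C/c1c(N)ncnc1Oc1ccc2[nH]c(C)cc2c1F` has not yet been measured; it differs from compound 2 by methyl in place of hydrogen on an oxygen on a saturated carbon. This change bears directly on the earlier step, because a 12-fold higher number from compound 1 to compound 2 (1.08 log units; beyond the scatter) showed that adding the hydroxy raised the number, and compound 4 caps that same hydroxy with a methyl. A partial reversal toward compound 1 is expected, though the chain keeps its extra oxygen, so a full return is not assumed. Compound 4 is therefore estimated in this assay at 110 nM, with a likely range from 40 nM to 300 nM, an expected step of a 3.1-fold lower number from compound 2 to compound 4 (0.48 log units; beyond the scatter).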

Compound 4, half-maximal inhibitory concentration: 300 nM
Beside the measured number, compound 4's estimate is 2.7-fold (0.44 log units) below it; the measured number falls inside the stated range.
By their numbers in this assay, from the lowest: compound 1; then compounds 4 and 2 (each within the scatter of the next); then compound 3.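

In this assay, methyl in place of hydrogen on an oxygen on a saturated carbon gives a 1.1-fold lower number from compound 2 to compound 4 (0.05 log units; within the scatter), so at this position the hydroxy and methoxy compounds cannot be told apart. The hydrogen on that oxygen therefore does not account for the gap to compound 1: the chain ending in methoxy still gives an 11-fold higher number from compound 1 to compound 4 (1.03 log units; beyond the scatter), a large step like a 12-fold higher number from compound 1 to compound 2 (1.08 log units; beyond the scatter). Nothing available explains why these two different chain ends read alike.

On these data alone, whether an amine or a carboxylic acid at the same place on the chain would read like the hydroxy and methoxy remains open. So does whether a longer chain carrying a methoxy would stay with them or move toward compound 1.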